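This account rests on a few compounds, and the source may have more. Where it says the series, first, only, none or still open, it means among the compounds named here.

Working notes on the series, all on the shared core. In an in vitro ADME assay on microsomes from liver (Rattus norvegicus) for metabolic stability (a higher number here means faster removal of the compound, a lower number slower removal), compound 1 `CC(C)NC(=O)[C@H]1CC[C@@H](n2/c(=N/C(=O)c3ccc(F)cc3)[nH]c3ccc(CN4CCC[C@H]4C(C)(C)O)cc32)CC1` gives 455 mL.min-1.g-1, and compound 2 `CC(C)NC(=O)[C@H]1CC[C@@H](n2/c(=N/C(=O)c3ccc(F)cc3)[nH]c3ccc(CN4CCCCC4)cc32)CC1` gives 451 mL.min-1.g-1. These two lie within the scatter of each other, as a 1.0-fold lower number from compound 1 to compound 2 (0.00 log units; within the scatter) shows. In the same this assay compound 3 `CC(C)NC(=O)[C@H]1CC[C@@H](n2/c(=N/C(=O)c3ccc(F)cc3)[nH]c3ccc(CN4CCNC(=O)C4)cc32)CC1` gives 45 mL.min-1.g-1, the lowest of the three numbers. Two steps end at that number, a 10-fold lower number from compound 1 to compound 3 (1.00 log units; beyond the scatter) and a 10-fold lower number from compound 2 to compound 3 (1.00 log units; beyond the scatter), and both are beyond the scatter and of the same size.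

Compound 4 `CC(C)NC(=O)[C@H]1CC[C@@H](n2/c(=N/C(=O)c3ccc(F)cc3)[nH]c3ccc(CNCC(C)(C)O)cc32)CC1` has not been measured. Its difference from compound 3 is (2-hydroxy-2-methylpropyl)amino in place of 3-oxopiperazin-1-yl on a saturated chain carbon bound to an aromatic carbon. For the measured compounds named here, no measured step leads to (2-hydroxy-2-methylpropyl)amino, so the evidence is indirect. The two steps into 3-oxopiperazin-1-yl, a 10-fold lower number from compound 1 to compound 3 (1.00 log units; beyond the scatter) and a 10-fold lower number from compound 2 to compound 3 (1.00 log units; beyond the scatter), read in reverse, suggest that giving up this group raises the number. The entering group matches neither the group of compound 1 nor that of compound 2, so the same direction is expected in this assay, but not necessarily the full size. A higher number is therefore expected, with the estimated step being a 3.3-fold higher number from compound 3 to compound 4 (0.52 log units; beyond the scatter). The estimate for compound 4 is 150 mL.min-1.g-1, with an expected range of 60 mL.min-1.g-1 to 400 mL.min-1.g-1.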

Compound 4, intrinsic clearance in microsomes: 68 mL.min-1.g-1
Beside the measured number, compound 4's estimate is 2.2-fold (0.34 log units) above it; the measured number falls inside the stated range.
By their numbers in this assay, from the lowest: compounds 3 and 4 (each within the scatter of the next); then compounds 2 and 1 (each within the scatter of the next).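

In this assay the low number no longer belongs to 3-oxopiperazin-1-yl alone: with a 1.5-fold higher number from compound 3 to compound 4 (0.18 log units; within the scatter) the open-chain (2-hydroxy-2-methylpropyl)amino, which has no ring, cannot be told apart from it, so a ring at this place is not required for a number in this range. The entering group also stands clear of the groups of the two faster-cleared compounds, with a 6.6-fold lower number from compound 2 to compound 4 (0.82 log units; beyond the scatter) and a 6.7-fold lower number from compound 1 to compound 4 (0.83 log units; beyond the scatter) as the two steps, and a hydroxy group in the substituent does not by itself go with the low number, since compound 1 carries one and gives 455 mL.min-1.g-1 in the same read-out. Nothing at hand gives a measured reason for any of these steps.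

From the compounds shown here alone, whether morpholin-4-yl, or a plain ethylamino chain without the hydroxy group, would fall with compounds 3 and 4 or with compounds 1 and 2 remains open. Going by these compounds, it is equally open whether a longer chain or a carboxylic acid on this saturated chain carbon would bring the number below those of compounds 3 and 4.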